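Adding a ring methyl to compound 3

The compounds below may be only part of what the source reports. "The series", "measured", "known", "first", "only" and "open" are said of these compounds alone.

Of the compounds shown here, three have so far been measured in an ADME assay on microsomes from liver (Rattus norvegicus) for metabolic stability, read by LC-MS, using NADPH, with stated times of 10 min and 60 min; a higher number here means faster removal of the compound, a lower number slower removal. Compound 1 (`CCc1nc(CN(C)C2CCCc3cccnc32)cc(N2CCN(C)CC2)n1`) gives 2090 mL/min/kg there, compound 2 (`Cc1nc(CN(C)C2CCCc3cccnc32)c(C#N)c(N2CCN(C)CC2)n1`) gives 1640 mL/min/kg there, and compound 3 (`Cc1nc(CN(C)[C@H]2CCCc3cccnc32)cc(N2CCN(C)[C@@H](C)C2)n1`) gives 1550 mL/min/kg there. Compound 3 stands within the usual scatter of both other compounds, so the three numbers cannot be ranked.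

Compound 4 (`Cc1nc(CN(C)[C@H]2CCCc3cccnc32)cc(N2C[C@@H](C)N(C)[C@@H](C)C2)n1`) departs from compound 3 in one place (methyl in place of hydrogen on a saturated ring carbon), with methyl in place of hydrogen on a saturated ring carbon. The group changes from 3,4-dimethylpiperazin-1-yl to 3,4,5-trimethylpiperazin-1-yl. For the measured compounds named here, no measured pair differs in only one place, so this change has no direct precedent in the data.

No step beyond the scatter is expected in this assay, in either direction. This expectation rests on compound 3 at 1550 mL/min/kg as the starting point and on how closely the three measured compounds agree despite their differing structures. The estimated step of a 1.1-fold lower number from compound 3 to compound 4 (0.03 log units; within the scatter) is accordingly small. Compound 4 is estimated at 1450 mL/min/kg in this assay, with an expected range between 800 mL/min/kg and 2400 mL/min/kg as the likely outcome.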

Compound 4, clearance: > 497 mL/min/kg
Compound 4: only a limit was reported; the forecaster's own chance of this, stated with the estimate: 3%; the middle value lies beyond the limit too.
By their numbers in this assay, from the lowest: compounds 3, 2 and 1 (each within the scatter of the next).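

In this assay compound 4 gives > 497 mL/min/kg, which is a limit of the assay and not a number. The step between compound 3 and compound 4 cannot be read. The compounds shown leave open whether the added methyl on the saturated ring carbon changes clearance at all.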